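This account rests on a few compounds, and the source may have more. Where it says the series, first, only, none or still open, it means among the compounds named here.

In an ADME assay on microsomes from liver (Rattus norvegicus) for metabolic stability, read by LC-MS, with a stated time of 1 h, at 37 degrees C, tested at 4 uM (a lower number here means that less of the compound is left, a higher number that more of the compound is left), compound 1 `O=C(O)c1cc(-c2cccc(COc3ccc4c(=O)n(CC5CC5)sc4c3)c2)ccc1Cl` gives 75% and compound 2 `O=C(O)c1cc(-c2cccc(COc3ccc4c(=O)n(C5CCC5)sc4c3)c2)ccc1Cl` gives 67% which lies within the scatter of the value for compound 1. Compound 3 `O=C(O)c1cc(-c2cccc(COc3ccc4c(=O)n(C5CC5)sc4c3)c2)ccc1Cl` has cyclopropyl in place of cyclobutyl on an aromatic nitrogen next to the ring sulfur, a difference from compound 2 counted as cyclopropyl in place of cyclobutyl on an aromatic nitrogen in the structures. Among the compounds with values here, the one measured step on that nitrogen is a number 8 percentage points lower from compound 1 to compound 2 (within the scatter) and so no step beyond the scatter is expected here, in either direction. The expected change is a number 3 percentage points higher from compound 2 to compound 3 (within the scatter) and it is only a small estimated step. Compound 3 is expected at 70% with an estimated range from 55% to 84% as its likely span.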

Compound 3, percent of the compound remaining: 86%
Compound 3: the middle estimate sits 16 percentage points below what was measured; the measured number lies above the stated range.
By their numbers in this assay, from the lowest: compounds 2 and 1 (each within the scatter of the next); then compound 3.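

On this aromatic nitrogen next to the ring sulfur, the substituent can shift the result in this assay beyond the scatter: cyclopropyl in place of cyclobutyl gives a number 19 percentage points higher from compound 2 to compound 3 (beyond the scatter) while the earlier step at this position stayed within it. Cyclopropyl in place of cyclopropylmethyl also gives a number 11 percentage points higher from compound 1 to compound 3 (beyond the scatter) so compound 3 stands apart from both other compounds. Nothing measured accounts for this difference.

The compounds shown leave open whether the three-membered ring itself matters or only its three carbons. They also leave open how methyl or isopropyl on this nitrogen would compare.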